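The source may report more compounds than this note shows. Statements on the series, on what has been measured and on what is new or still open speak of the compounds shown alone.

Of the compounds shown here, three built on a shared core have been measured in a functional assay on the whole organism for antagonist activity, with Mus musculus as the target; a lower number here means that less compound is needed, a higher number that more compound is needed for the effect. Compound 1 `CCCCCC(=O)NCC(=O)N(C)c1ccc(Cl)cc1C(=O)c1ccccc1Cl` gives 1.9 mg/kg. Compound 3 `CCCCCCC(=O)NCC(=O)N(C)c1ccc(Cl)cc1C(=O)c1ccccc1Cl` gives 1.9 mg/kg. Going by the values given here, the one measured step, no change at the digits printed from compound 1 to compound 3 (within the scatter), is a small lengthening of the chain that leaves the result unchanged. For compound 2 `CC(=O)NCC(=O)Nc1ccc(Cl)cc1C(=O)c1ccccc1Cl` the measurement gives only a limit, > 100 mg/kg, not a number. Among the compounds with values here, compound 3 therefore sits level with compound 1, the only other compound with a number, while the remaining value is the limit marked by the limit of > 100 mg/kg in this assay, at which 1 of the 3 values shown sits.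

Compound 4 `CC(=O)NCC(=O)N(C)c1ccc(Cl)cc1C(=O)c1ccccc1Cl` differs from compound 3 by hydrogen in place of pentyl on a saturated chain carbon bound to a carbonyl carbon. Within the data shown here, no measured step covers this change. The measured step from compound 1 to compound 3 concerned a much smaller alteration further out on the chain, so it says little about removing the whole pentyl. The acetyl that enters is also present in compound 2, which reached only a limit, although compound 2 differs from compound 4 elsewhere as well. Compound 4 is expected to need more compound than compound 3, an estimated step of a 6.3-fold higher number from compound 3 to compound 4 (0.80 log units; beyond the scatter) in this assay. Compound 4 is estimated at 12 mg/kg, between 2.5 mg/kg and 80 mg/kg, with a real chance that only a limit is obtained.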

Compound 4, dose for half-maximal effect: 2.3 mg/kg
Estimate against measurement, compound 4: 5.2-fold (0.72 log units) above; measured number below the stated range.
By their numbers in this assay, from the lowest: compounds 1, 3 and 4 (each within the scatter of the next). At a limit, above all of these: compound 2.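

In this assay, the whole pentyl on the saturated chain carbon bound to a carbonyl carbon can give way to hydrogen and the result stays level (a 1.2-fold higher number from compound 3 to compound 4 (0.08 log units; within the scatter)), and the same holds when hydrogen replaces butyl at this place (a 1.2-fold higher number from compound 1 to compound 4 (0.08 log units; within the scatter)). Compounds 1, 3 and 4 therefore show that the short acetyl serves as well as the longer chains here, so the length of this chain is not what sets the dose among these three. Going by these compounds alone, with the acetyl held constant, the single change that does separate two compounds is methyl in place of hydrogen on an amide-type nitrogen (an at least 43-fold lower number from compound 2 to compound 4 (1.63 log units; beyond the scatter)), and for compound 2 the value is a limit and not a number: the limit of > 100 mg/kg in this assay, at which 1 of the 4 values shown sits.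

On these data alone, it remains open whether the level result would hold for a longer chain than hexyl, or for a chain ending in an amine or a carboxylic acid at this place. Also open, as far as these compounds go, is whether ethyl could stand in for the methyl on the amide-type nitrogen, and whether hydrogen on that nitrogen would cost as much alongside a pentyl as it does alongside the acetyl.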